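The source may hold more compounds than are shown below. What is called first, only, known or untested is meant among the compounds shown, and "the series" means these compounds.

Measured in an ADME assay on microsomes from liver (Homo sapiens) for metabolic stability, read by LC-MS, with NADPH named in the record, with a stated time of 60 min, tested at 1 uM, in the absence of a further agent; on this read-out higher numbers stand for a more stable compound and lower numbers for a less stable compound:
Compound 1 `COc1ccc(-c2c(C)nc3c(N4CC[C@@H](NC(=O)C(F)(F)F)C4)cc(C)nn23)cc1OC`: > 95%
Compound 2 `COc1ccc(-c2c(C)nc3c(N4CC[C@@H](NC(=O)NC(C)C)C4)cc(C)nn23)cc1OC`: > 95%
Compound 3 `COc1ccc(-c2c(C)nc3c(N4CCCC4)cc(C)nn23)cc1OC`: > 95%

Each entry is a limit, not a number. Compound 3 stands at a limit, > 95%. Compound 4 `COc1ccc(-c2c(C)nc3c(N4CC[C@@H](O)C4)cc(C)nn23)cc1OC` carries hydroxy in place of hydrogen on a saturated ring carbon. The nearest steps, a step that the two limits leave unreadable from compound 1 to compound 3 and a step that the two limits leave unreadable from compound 2 to compound 3, also change what sits on a saturated ring carbon, and neither size is readable. On these two steps, with the limit of > 95% in this assay, at which 3 of the 3 values shown sit, holding for every value, no direction and no step beyond the scatter is expected in this assay. The estimated step is a number at least 1 percentage points lower from compound 3 to compound 4 (that floor lies within the scatter). Estimated for compound 4: 94%, with an expected range of 80% to 100%.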

Compound 4, percent of the compound remaining: > 95%
Compound 4: only a limit was reported; the forecaster's own chance of this, stated with the estimate: 60%; middle value at least 1 percentage points away from the limit.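

In this assay compound 4 gives > 95%, a limit. Within the data shown here, compound 1, compound 2, compound 3 and compound 4 all stand at this same limit, and no step among them can be read. The compounds shown leave open how the groups on the saturated ring carbon differ in stability.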